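The source may hold more compounds than are shown below. What is called first, only, known or untested is meant among the compounds shown, and "the series" means these compounds.

Compound 3 `CC(C)n1cnc2c(NCc3ccc(C(=O)Nc4ccccc4N)cc3)nc(Cl)nc21` and compound 2 `CCCCn1cnc2c(NCc3ccc(C(=O)Nc4ccccc4N)cc3)nc(Cl)nc21` share a core and differ in one place: butyl in place of isopropyl on an aromatic nitrogen. In a functional assay on HepG2 cells (Homo sapiens) for antiproliferative activity, read by CCK-8 assay, with a stated time of 72 h, tested at 2 uM (on this read-out higher numbers stand for a stronger effect at the one concentration tested and lower numbers for a weaker effect), compound 3 gives 63.8%, while compound 2 gives 6.8%, a step of a number 57 percentage points lower from compound 3 to compound 2 (beyond the scatter). Compound 1 `CC(C)n1cnc2c(Nc3ccccc3)nc(NCOCc3ccc(/C=C/C(=O)Nc4ccccc4N)cc3)nc21` carries a different core; the difference between the two cores is not broken down here. In this assay compound 1 gives 1.46%. Compound 4 `CCCCn1cnc2c(Nc3ccccc3)nc(NCOCc3ccc(/C=C/C(=O)Nc4ccccc4N)cc3)nc21` is not yet measured; it stands to compound 1 as compound 2 stands to compound 3, with the same change at the same place: butyl in place of isopropyl on an aromatic nitrogen. The earlier step was large and downward, but compound 1 already sits near the bottom of the scale, leaving little room for a fall of that size. The expected step is a number 0.5 percentage points higher from compound 1 to compound 4 (within the scatter), resting on compound 1 already giving only 1.46%. Compound 4 is estimated at 2%, between 0% and 9%.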

Compound 4, a percentage reported as inhibition, at one concentration (the size of the read-out at that concentration, not a potency): 27.9%
Compound 4: the middle estimate sits 25.9 percentage points below what was measured, outside the stated range (above it).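

In this assay, butyl in place of isopropyl on the aromatic nitrogen gives a step of a number 26.4 percentage points higher from compound 1 to compound 4 (beyond the scatter), so the change that lowered the number on one core raises it on the other: the same change on two cores in this assay, a number 57 percentage points lower (beyond the scatter) from compound 3 to compound 2 and a number 26.4 percentage points higher (beyond the scatter) from compound 1 to compound 4, 83.4 percentage points apart, beyond the scatter of two such steps. The effect of this change therefore cannot be carried from one core to the other in this series, at least for these two pairs. The data do not show why the direction reverses, or which of the differences between the two cores matters.

Which part of the cores decides the direction remains open. So does how a longer chain such as hexyl, or a ring such as cyclopentyl, on that same nitrogen would behave on either core.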